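Thiophene for hydroxyphenyl: working notes on compound 4

A few compounds are considered here, and "the series" means these few. Any claim that something is new, unique, unknown or untested is made for them only; others in the source may bear on it.

Compound 3 `CS(=O)(=O)c1ccc2nc(-c3ccc(-c4ccccc4O)cc3)[nH]c2c1` gives 336 nM in an assay on isolated protein for inhibition of acyl-CoA desaturase 1 (Rattus norvegicus); a higher number here means a weaker inhibitor, a lower number a stronger inhibitor. Among the three compounds measured it holds the second highest number; compound 2 `Cc1cccc(-c2ccc(-c3nc4ccc(S(C)(=O)=O)cc4[nH]3)cc2)c1` gives 319 nM and sits nearest, with a 1.1-fold higher number from compound 2 to compound 3 (0.02 log units; within the scatter), while compound 1 `CCS(=O)(=O)c1ccc2nc(-c3ccc(-c4ccccc4F)cc3)[nH]c2c1` with 1250 nM stands furthest off. Compound 4 `Cc1ccsc1-c1ccc(-c2nc3ccc(S(C)(=O)=O)cc3[nH]2)cc1` is unmeasured and differs from compound 3 by 3-methylthiophen-2-yl in place of 2-hydroxyphenyl on an aromatic carbon. For the measured compounds named here, the only single-point step in hand, a 1.1-fold higher number from compound 2 to compound 3 (0.02 log units; within the scatter), exchanged one ring substituent for another at the same place without effect beyond the scatter. Compound 1 changes in two places relative to compound 3, so its gap cannot be assigned to either change. The expected step is therefore small: a 1.0-fold higher number from compound 3 to compound 4 (0.02 log units; within the scatter). Compound 4 is estimated at 350 nM in this assay, with a range from 120 nM to 1000 nM.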

Compound 4, half-maximal inhibitory concentration: 472 nM
Estimate against measurement, compound 4: 1.3-fold (0.13 log units) below; measured number inside the range.
By their numbers in this assay, from the lowest: compounds 2, 3 and 4 (each within the scatter of the next); then compound 1.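

In this assay, 3-methylthiophen-2-yl on this aromatic carbon, para to a large group, leaves the number within the scatter of both six-membered aryl groups: a 1.4-fold higher number from compound 3 to compound 4 (0.15 log units; within the scatter), and a 1.5-fold higher number from compound 2 to compound 4 (0.17 log units; within the scatter). Across compounds 2, 3 and 4, neither the five-membered ring with its sulfur nor the absence of the hydrogen-bond donor of 2-hydroxyphenyl separates the values. Nothing available explains this flat response.

From the compounds shown here alone, whether an amine or a carboxylic acid at this position would move the number beyond the scatter remains open. The gap to compound 1 also stays unassigned, as that compound differs from the others in more than one place.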